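Replacing Bromine with Furan on a Shared Purine-Type Core

A few compounds are considered here, and "the series" means these few. Any claim that something is new, unique, unknown or untested is made for them only; others in the source may bear on it.

Measured so far: compound 1, `CCCn1c(Br)nc2c(NCc3ccccc3)ncnc21`, 7490 nM; compound 2, `CCCn1c(Br)nc2c(NCCCc3ccccc3)ncnc21`, 1760 nM.

In a functional assay on CHO cells for antagonist activity at adenosine receptor A2b (Homo sapiens) (on this read-out lower numbers stand for stronger inhibition and higher numbers for weaker inhibition), compound 2 gives 1760 nM, the lowest of the two numbers, with compound 1 at 7490 nM, a gap beyond the scatter. Compound 3, `CCCn1c(-c2ccco2)nc2c(NCCCc3ccccc3)ncnc21`, differs from compound 2 by furan-2-yl in place of bromo on an aromatic carbon. For the measured compounds named here, no measured pair shows this change, so the expected step rests on the change alone; a step toward a lower number beyond the scatter is expected, a 5.0-fold lower number from compound 2 to compound 3 (0.70 log units; beyond the scatter). For compound 3 the estimate in this assay is 350 nM, within a range from 70 nM to 1700 nM.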

Compound 3, inhibition constant: 1870 nM
Beside the measured number, compound 3's estimate is 5.3-fold (0.73 log units) below it; measured number outside the range, above it.
By their numbers in this assay, from the lowest: compounds 2 and 3 (each within the scatter of the next); then compound 1.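

In this assay, furan-2-yl in place of bromo on the aromatic carbon between two ring nitrogen atoms gives a 1.1-fold higher number from compound 2 to compound 3 (0.03 log units; within the scatter) and so leaves the two groups indistinguishable on this read-out. For the compounds shown here, this position, which the earlier compounds did not vary, therefore accepts a five-membered aromatic ring in place of a bromine atom with no difference beyond the scatter. Nothing available explains this result. As far as these compounds go, it remains open whether an amine or a phenyl group at this position would behave the same way, and whether the furan-2-yl swap would give a similar step on the core of compound 1.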